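A Hydroxy-to-Methyl Swap at the Edge of Detection

The source may hold more compounds than are shown below. What is called first, only, known or untested is meant among the compounds shown, and "the series" means these compounds.

Compound 1 `Cc1cccc(S(=O)(=O)Nc2ccc(-c3nc4ccccc4o3)cc2)c1`: > 100000 nM
Compound 2 `C=Cc1ccc(S(=O)(=O)Nc2ccc(-c3nc4ccccc4o3)cc2)cc1`: > 100000 nM
Compound 3 `O=S(=O)(Nc1ccc2oc(-c3ccccc3)nc2c1)c1ccc(O)cc1`: 88000 nM

Three sulfonamides have been measured in an assay on cells for inhibition of HSP60/HSP10 (Homo sapiens), with a stated time of 60 min; a higher number here means a weaker inhibitor, a lower number a stronger inhibitor. Compound 1 reaches only a limit of the assay at > 100000 nM. Compound 2 likewise returns a limit, > 100000 nM. Among the compounds with values here, compound 3 is the one compound with an actual number, giving 88000 nM in this assay, a weak result.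

Compound 4 `Cc1ccc(S(=O)(=O)Nc2ccc3oc(-c4ccccc4)nc3c2)cc1` differs from compound 3 in one place: methyl in place of hydroxy on an aromatic carbon. Within the data shown here, the only step between measured compounds, a step that the two limits leave unreadable from compound 1 to compound 2, cannot be sized and so says nothing about this change. What the data do offer is the limit of > 100000 nM in this assay, at which 2 of the 3 values shown sit, which shows how near to that ceiling the whole set lies.

Compound 4 is therefore expected to stay at the weak end, with a step of a 1.4-fold higher number from compound 3 to compound 4 (0.13 log units; within the scatter) that is within the usual scatter and a fair chance of returning only a limit. The estimate for compound 4 in this assay is 120000 nM, with a range from 50000 nM to 300000 nM.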

Compound 4, half-maximal inhibitory concentration: > 100000 nM
Compound 4: no number, only a limit; the forecaster's own chance of this, stated with the estimate: 60%; the middle value is on the limit's open side.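

Within the data shown here, with 4-methylphenyl in place of 4-hydroxyphenyl, an at least 1.1-fold higher number from compound 3 to compound 4 (0.05 log units; that floor lies within the scatter) is the first step in the set that can be read, though only as a floor. In this assay compound 4 gives > 100000 nM as a limit of the assay and not a number. Methyl at this position, para to a large group, therefore brings no measurable gain over hydroxy, and the series stays at its ceiling: the limit of > 100000 nM in this assay, at which 3 of the 4 values shown sit.

The compounds shown leave open whether an amine or a carboxylic acid on the same aromatic carbon would give an actual number clear of that limit. They also leave open whether a methoxy group there would read like hydroxy or like methyl.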